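The compounds below may be only part of what the source reports. "The series", "measured", "known", "first", "only" and "open" are said of these compounds alone.

Working notes on the series.

Compound 1 `C=C(c1ccc2c(c1)C=CC(C)(C)O2)c1ccc(OC)cc1NC(=O)CO` and compound 2 `C=C(c1ccc2c(c1)C=CC(C)(C)O2)c1ccc(OC)cc1NC(=O)CN(C)C` share one core and differ at the amide chain: hydroxy in place of dimethylamino on a saturated chain carbon bound to a carbonyl carbon. In a functional assay on HeLa cells (Homo sapiens) for antiproliferative activity, read by MTT assay, with a stated time of 48 h (a lower number here means a stronger inhibitor, a higher number a weaker inhibitor), compound 2 gives 640 nM, and compound 1 gives 100 nM. The step of a 6.4-fold lower number from compound 2 to compound 1 (0.81 log units; beyond the scatter) is therefore the one reference point for this change.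

Compound 3 `C=C(c1cc(OC)c(OC)c(OC)c1)c1ccc(OC)c(O)c1NC(=O)CN(C)C` carries a different core; the difference between the two cores is not broken down here. In this assay compound 3 gives 120 nM, which sits within the scatter of compound 1 and beyond it from compound 2.

Compound 4 `C=C(c1cc(OC)c(OC)c(OC)c1)c1ccc(OC)c(O)c1NC(=O)CO` has not been measured. It differs from compound 3 in the same way that compound 1 differs from compound 2: hydroxy in place of dimethylamino on a saturated chain carbon bound to a carbonyl carbon. The place is the same in both cases, so this is the same change, made on another core.

Expectation for compound 4 in this assay: the step is estimated as a 3.4-fold lower number from compound 3 to compound 4 (0.54 log units; beyond the scatter), set beside the measured step of a 6.4-fold lower number from compound 2 to compound 1 (0.81 log units; beyond the scatter), on the ground that the change is the same and the only measured case of it gave a clear gain. The core of compound 3 differs from that of compound 1. The full size of the earlier step is therefore not assumed, and the range is kept wide. Compound 4 is expected to give 35 nM, with a range from 12 nM to 110 nM.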

Compound 4, half-maximal inhibitory concentration: 20 nM
Compound 4: the middle estimate sits 1.8-fold (0.24 log units) above what was measured; the range from low to high includes it.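

In this assay, hydroxy in place of dimethylamino on a saturated chain carbon bound to a carbonyl carbon gives a 6.0-fold lower number from compound 3 to compound 4 (0.78 log units; beyond the scatter), and this step matches the one measured on the other core: the same change on two cores in this assay, a 6.4-fold lower number (0.81 log units; beyond the scatter) from compound 2 to compound 1 and a 6.0-fold lower number (0.78 log units; beyond the scatter) from compound 3 to compound 4, 1.1-fold (0.03 log units) apart, within the scatter of two such steps
Across these two pairs, the change therefore carries from the core of compound 1 to the core of compound 3 with its size kept, and the lower number goes with the hydroxy compound in both. This does not show that the step is independent of the core in general, since it rests on one pair for each of two cores, and it gives no reason for the gain or any separate reading of what the cores themselves contribute.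

The compounds shown leave open how other groups on this chain carbon would compare with hydroxy and dimethylamino, for example a primary amine, a methoxy group or a carboxylic acid, and whether a longer chain ending in hydroxy would keep the lower number. They also leave open whether the step would hold on a third core, or in any read-out other than this assay.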